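Two Fluorines Added to a Prostaglandin D2 Receptor Antagonist

The source may hold more compounds than are shown below. What is called first, only, known or untested is meant among the compounds shown, and "the series" means these compounds.

Two compounds have been measured in an in vitro functional assay on HEK285-7 cells for antagonist activity at prostaglandin D2 receptor 2 (Homo sapiens), read by BRET and beta-arrestin recruitment; on this read-out higher numbers stand for weaker inhibition and lower numbers for stronger inhibition:

compound 1 `O=C(O)Cc1sc(C(c2ccccc2)c2ccc(F)cc2)nc1-c1ccc(Cl)cc1` gives 36 nM
compound 2 `O=C(O)Cc1sc(C(c2ccccc2)c2ccccc2)nc1-c1ccccc1` gives 370 nM

Compound 2 stands at the higher of the two numbers, and compound 1 gives the lower number, a gap that lies beyond the usual scatter. Among the measured compounds shown here, the two differ from each other in more than one place, so the comparison shows only that compound 1, which carries halogen substituents on two of its aromatic rings, is the more potent of the pair in this assay .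

Compound 3 `O=C(O)Cc1sc(C(c2ccccc2)c2ccccc2)nc1-c1ccc(F)c(F)c1` takes compound 2 and changes one thing: 3,4-difluorophenyl in place of phenyl on an aromatic carbon. For the measured compounds named here, no measured pair shows this exact change. Compound 3 moves toward compound 1 in carrying halogens on the ring attached to the shared core, although compound 1 also differs elsewhere. On that basis a lower number than compound 2 is expected, with the step from compound 2 to compound 3 estimated at a 4.1-fold lower number from compound 2 to compound 3 (0.61 log units; beyond the scatter), most likely beyond the scatter. Compound 3 is therefore estimated at 90 nM, within a range from 25 nM to 300 nM.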

Compound 3, half-maximal inhibitory concentration: 43 nM
Estimate against measurement, compound 3: 2.1-fold (0.32 log units) above; low and high end bracket the measured number.
By their numbers in this assay, from the lowest: compounds 1 and 3 (each within the scatter of the next); then compound 2.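

The earlier pair, compound 1 and compound 2, differ in more than one place, so the gap between them could not be tied to any single ring. Here only one group changes: in this assay, putting 3,4-difluorophenyl in place of phenyl on the aromatic carbon next to the ring nitrogen, with the rest of the molecule left as it is, gives an 8.6-fold lower number from compound 2 to compound 3 (0.93 log units; beyond the scatter), so this position alone can shift the number well beyond the usual scatter, and adding fluorine to this ring is enough to do so. No measurement of any other kind is available to say why the number falls, so this step remains an observation about potency and nothing more.

The compounds shown leave open whether both fluorines are needed, or whether a single fluorine on this phenyl ring would give a similar step, and whether a methoxy group or a nitrile in their place would lower the number too. A single pair also cannot tell whether the same change would give a step of similar size if the other aromatic rings carried substituents of their own.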